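This account rests on a few compounds, and the source may have more. Where it says the series, first, only, none or still open, it means among the compounds named here.

Measured compounds:
- compound 1, `Cc1ccc(C(=O)NCc2ccccc2C(F)(F)F)cc1C#CC(C)N(O)C(N)=O`: 1700 nM
- compound 2, `CC(C#Cc1cccc(C(=O)NCc2cccc(F)c2)c1)N(O)C(N)=O`: 4000 nM
- compound 3, `CNc1nc(C)nc(N[C@H]2CCC[C@@H](C(=O)NCc3ccc(C#N)cc3C(F)(F)F)C2)n1`: "not determined" (no result reported)

In an assay for inhibition of Polyunsaturated fatty acid 5-lipoxygenase (Homo sapiens), read by HPLC, with stated times of 15 min and 10 min (a higher number here means a weaker inhibitor, a lower number a stronger inhibitor), compound 2 gives the highest of the two reported numbers, and its nearest neighbour, compound 1, sits at a lower number by a gap beyond the usual scatter. Compound 3 carries no number here. Compound 4, `CC(C#Cc1cccc(C(=O)NCc2ccc(Cl)cc2Cl)c1)N(O)C(N)=O`, has not yet been measured. It differs from compound 2 in one place: 2,4-dichlorophenyl in place of 3-fluorophenyl on a saturated chain carbon bound to an amide-type nitrogen. Among the compounds with values here, since no comparison of measured compounds tracks this change, there is no measured guide to its effect. The expected step from compound 2 to compound 4, a 1.6-fold lower number from compound 2 to compound 4 (0.20 log units; within the scatter), is small and toward a lower number, roughly at the edge of the scatter. The estimate for compound 4 is 2500 nM, with a range from 800 nM to 8000 nM.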

Compound 4, half-maximal inhibitory concentration: 600 nM
For compound 4 the middle estimate is 4.2-fold (0.62 log units) above the measured one, outside the stated range (below it).
By their numbers in this assay, from the lowest: compound 4; then compound 1; then compound 2.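

In this assay, 2,4-dichlorophenyl in place of 3-fluorophenyl on a saturated chain carbon bound to an amide-type nitrogen gives a 6.7-fold lower number from compound 2 to compound 4 (0.82 log units; beyond the scatter). Within the data shown here, this is the only one-place comparison here, and it shows that the number responds to a change at this position. No supporting measurement explains the shift. Because the change replaces one fluorine with two chlorines, the two compounds cannot separate the kind of halogen from the number of halogens. A plain phenyl ring or a phenyl ring carrying a single chlorine would be needed to address that question.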